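Replacing an Acetyl Methyl with a Furan Ring

The source may hold more compounds than are shown below. What is called first, only, known or untested is meant among the compounds shown, and "the series" means these compounds.

Measured in a functional assay on SMMC-7721 cells (Homo sapiens) for antiproliferative activity, read by MTT assay, with a stated time of 72 h; a higher number here means a weaker inhibitor, a lower number a stronger inhibitor:
compound 1, `CC(=O)N(C)c1ccc2[nH]c(-c3n[nH]c4ccccc34)cc2n1`, gives 23400 nM
compound 2, `CN(C(=O)c1ccc(Br)cc1)c1ccc2[nH]c(-c3n[nH]c4ccccc34)cc2n1`, gives 3460 nM
compound 3, `COc1cccc(C(=O)N(C)c2ccc3[nH]c(-c4n[nH]c5ccccc45)cc3n2)c1`, gives 22000 nM

Compound 1 stands with the highest number of the three, and compound 3 sits within the scatter of it, while compound 2 lies beyond it: a 6.8-fold lower number from compound 1 to compound 2 (0.83 log units; beyond the scatter). Compound 4, `CN(C(=O)c1ccco1)c1ccc2[nH]c(-c3n[nH]c4ccccc34)cc2n1`, differs from compound 1 in one place: furan-2-yl in place of methyl on a carbonyl carbon. The two measured steps from compound 1 both swap the methyl for a ring on the same carbonyl carbon; one gave a modest gain, a 6.8-fold lower number from compound 1 to compound 2 (0.83 log units; beyond the scatter), the other none, a 1.1-fold lower number from compound 1 to compound 3 (0.03 log units; within the scatter). A furan-2-yl is a smaller ring than either, so a change between none and modest in this assay is expected, as a 2.0-fold lower number from compound 1 to compound 4 (0.29 log units; within the scatter). Compound 4 is therefore estimated at 12000 nM, from 4000 nM to 30000 nM.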

Compound 4, half-maximal inhibitory concentration: 28200 nM
Compound 4: middle estimate off by 2.4-fold (0.37 log units), on the low side; the measured number falls inside the stated range.
By their numbers in this assay, from the lowest: compound 2; then compounds 3, 1 and 4 (each within the scatter of the next).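

In this assay, a ring on this carbonyl carbon is not enough by itself to lower the number: furan-2-yl in place of methyl gives a 1.2-fold higher number from compound 1 to compound 4 (0.08 log units; within the scatter), and furan-2-yl in place of 3-methoxyphenyl gives a 1.3-fold higher number from compound 3 to compound 4 (0.11 log units; within the scatter). The 4-bromophenyl alone stands apart among the three rings, with an 8.2-fold higher number from compound 2 to compound 4 (0.91 log units; beyond the scatter). Nothing measured here explains why that ring differs from the other two.

Still open, on these data alone, is whether a plain phenyl keeps the lower number of compound 2, or whether the bromine is needed. A longer chain or an amine on this carbonyl carbon is also untested among the compounds shown.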